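Ester to Acetamide on the Allyl Phenoxy Scaffold

This account rests on a few compounds, and the source may have more. Where it says the series, first, only, none or still open, it means among the compounds named here.

In an assay for inhibition of squalene synthase (Rattus norvegicus), using microsomes (a lower number here means a stronger inhibitor, a higher number a weaker inhibitor), compound 2 `C=CCc1cc(OC(=O)CC)ccc1OCCCNC(C)C` gives 0.05 nM, the lowest of the two numbers measured. Compound 1 `CC(C)NCCCOc1ccccc1Cc1ccccc1` gives 12 nM, a gap from compound 2 that lies beyond the scatter. For compound 3 `CC(C)NCCCOc1ccc(-c2cccnc2)cc1` the result > 2500 nM is only a limit of this assay and not a number, as recorded (the limit of > 2500 nM in this assay, at which 1 of the 3 values shown sits). Compound 4 `C=CCc1cc(NC(C)=O)ccc1OCCCNC(C)C` is not yet measured; it differs from compound 2 by acetamido in place of propanoyloxy on an aromatic carbon. Within the data shown here, no measured pair shows this exchange, so the expectation in this assay rests on compound 2 alone. Some loss is expected, a step of a 10-fold higher number from compound 2 to compound 4 (1.00 log units; beyond the scatter) toward a higher number. Compound 4 is estimated at 0.5 nM, within a range from 0.05 nM to 5 nM.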

Compound 4, half-maximal inhibitory concentration: 65 nM
Estimate against measurement, compound 4: 130-fold (2.11 log units) below; measured number outside the range, above it.
By their numbers in this assay, from the lowest: compound 2; then compound 1; then compound 4. At a limit, above all of these: compound 3.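

In this assay, placing acetamido in place of propanoyloxy on this aromatic carbon, meta to an allyl group, is a large change: a 1300-fold higher number from compound 2 to compound 4 (3.11 log units; beyond the scatter). The strength of compound 2 therefore does not survive this exchange at this position, so the group here matters greatly on this scaffold. Nothing measured here accounts for the size of this step.

The exchange alters both the linking atom and the acyl chain length at once, and the compounds shown cannot separate the two. A propanamido or an acetoxy group on the same carbon would tell them apart.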